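The source may hold more compounds than are shown below. What is called first, only, known or untested is meant among the compounds shown, and "the series" means these compounds.

Of the compounds shown here, three sharing one core have been tested in a functional assay on the whole organism with Mus musculus as the target, in the maximal electroshock model, with a stated time of 120 min; on this read-out lower numbers stand for an effect already at smaller amounts and higher numbers for an effect only at larger amounts of compound. Compound 1 `CC(C)(C)c1cccc(N2CCNCC2)n1` carries a tert-butyl group on an aromatic carbon; in this assay compound 1 gives only a limit, > 300 mg/kg, so no number is known for it. Compound 2 `CCCCSc1cccc(N2CCNCC2)n1` carries butylsulfanyl in that place, and in this assay compound 2 gives 100 mg/kg. Compound 3 `CCCc1cccc(N2CCNCC2)n1` carries propyl there, and in this assay compound 3 gives 10 mg/kg, the lowest of the two numbers measured. The measured steps were an at least 3.0-fold lower number from compound 1 to compound 2 (0.47 log units; beyond the scatter), an at least 30-fold lower number from compound 1 to compound 3 (1.47 log units; beyond the scatter) and a 10-fold lower number from compound 2 to compound 3 (1.00 log units; beyond the scatter).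

Compound 4 `CCCCCCCCCCc1cccc(N2CCNCC2)n1` is the one still to be measured. It differs from compound 3 in one place: heptyl in place of hydrogen on a saturated chain carbon, three bonds along the chain from an aromatic carbon. Within the data shown here, none of the measured steps extends an alkyl chain, so none bears directly on this change. The nearest guide is the comparison of compound 2 with compound 3, where swapping propyl for butylsulfanyl gave a 10-fold lower number from compound 2 to compound 3 (1.00 log units; beyond the scatter) in this assay, the shorter substituent giving the lower number. Growing the chain is therefore expected to push the number upward by a modest amount, the expected step being a 3.0-fold higher number from compound 3 to compound 4 (0.48 log units; beyond the scatter). Compound 4 is estimated at 30 mg/kg, with a range from 10 mg/kg to 300 mg/kg.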

Compound 4, minimum effective dose: 30 mg/kg
The estimate for compound 4 equals the measured number at the digits printed; low and high end bracket the measured number.
By their numbers in this assay, from the lowest: compound 3; then compound 4; then compound 2. At a limit, above all of these: compound 1.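

Adding heptyl on a saturated chain carbon, three bonds along the chain from an aromatic carbon, gives a 3.0-fold higher number from compound 3 to compound 4 (0.48 log units; beyond the scatter) in this assay. Unlike the earlier steps, which swap one whole group on the aromatic carbon for another, this step lengthens an existing alkyl chain, so it is the only direct reading of that change; a larger amount of compound is needed for an effect, yet compound 4 still gives a true number and not a limit, so this much longer chain does not abolish the effect in the mouse. Nothing shown here explains the size of this step.

A single step cannot show how the number moves with chain length, so a pentyl chain, which lies between propyl and the chain of compound 4, could fall on either side of compound 3 or compound 4. As far as these compounds go, it also remains open whether a chain carrying a hydroxyl group or an amine, or a cyclohexyl group in place of the chain, would give a lower or a higher number than compound 3.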